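A few compounds are considered here, and "the series" means these few. Any claim that something is new, unique, unknown or untested is made for them only; others in the source may bear on it.

Compound 1 `CC(C)CN1CCc2nc(C#Cc3ccccc3)sc2C1`: in an assay on HEK293 cells for positive allosteric modulation of metabotropic glutamate receptor 5 (Homo sapiens), read by FLIPR, with a stated time of 1 h (on this read-out higher numbers stand for an effect only at larger amounts of compound and lower numbers for an effect already at smaller amounts), compound 1 gives > 10000 nM, which is a limit of the assay and not a number.
Compound 2 `CCC(=O)N1CCc2nc(C#Cc3ccccc3)sc2C1`: compound 2 gives > 10000 nM, again a limit.
Compound 3 `O=C(C1CC1)N1CCc2nc(C#Cc3ccccc3)sc2C1`: compound 3 gives > 10000 nM, also a limit.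

Compound 3 therefore stands nowhere that can be ranked: all three values sit at the limit of > 10000 nM in this assay, at which 3 of the 3 values shown sit. The steps a step that the two limits leave unreadable from compound 1 to compound 2, a step that the two limits leave unreadable from compound 1 to compound 3 and a step that the two limits leave unreadable from compound 2 to compound 3 are all unreadable in size, so none of them bears a readable weight on what follows. Compound 4 `O=C(C1CCC1)N1CCc2nc(C#Cc3ccccc3)sc2C1` differs from compound 3 by cyclobutyl in place of cyclopropyl on a carbonyl carbon. With every measured step hidden by the limit, the step that the limit leaves unreadable from compound 3 to compound 4 is expected to be none that the assay can show. Compound 4 is thus expected at 15000 nM, with a range from 3000 nM to 60000 nM, and most probably again reported only as a limit.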

Compound 4, half-maximal effective concentration: > 10000 nM
Compound 4 gave a limit, no number; the forecaster's own chance of this, stated with the estimate: 80%; the middle value is on the limit's open side.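

No new step can be read: the steps joining compound 4 to compound 1, compound 2 and compound 3 cannot be sized, since each pair ends on limits. The compounds shown leave open which change to the shared core, if any, would give a measurable value: the limit of > 10000 nM in this assay, at which 4 of the 4 values shown sit.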